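Working notes: furan-2-yl for thiophen-2-yl in compound 1

This account rests on a few compounds, and the source may have more. Where it says the series, first, only, none or still open, it means among the compounds named here.

Values so far, all from a functional assay on THP-1 cells (Homo sapiens) for inhibition, read by sulforhodamine B assay, with a stated time of 48 h, tested at 50 uM (on this read-out lower numbers stand for less inhibition of growth and higher numbers for more inhibition of growth at the one concentration tested), as follows:
- compound 1 `COc1cc(/C=C/C(=O)/C=C/c2cccs2)ccc1OCc1cn(CCOc2cc(=O)oc3ccccc23)nn1` gives 76%
- compound 2 `COc1cccc(/C=C/C(=O)/C=C/c2ccc(OCc3cn(CCCCCOc4cc(=O)oc5ccccc45)nn3)c(OC)c2)c1` gives 37%
- compound 3 `COc1ccc(/C=C/C(=O)/C=C/c2ccc(OCc3cn(CCCOc4cc(=O)oc5ccccc45)nn3)c(OC)c2)cc1` gives 56%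

Compound 1 stands highest of the three, and compound 3 and compound 2 both lie lower by more than the scatter. Going by the values given here, these three compounds differ from one another in more than one place, so no single change can be read from them, and no measured pair covers the swap considered here.

The next compound is compound 4 `COc1cc(/C=C/C(=O)/C=C/c2ccco2)ccc1OCc1cn(CCOc2cc(=O)oc3ccccc23)nn1`, which differs from compound 1 in one place only. The change is furan-2-yl in place of thiophen-2-yl on a double-bonded chain carbon bound to a double-bonded chain carbon, with furan-2-yl in place of thiophen-2-yl on a double-bonded chain carbon bound to a double-bonded chain carbon. Both groups are five-membered aromatic rings, and the rest of the structure stays as it is. No step beyond the scatter is therefore expected in this assay, though a slight fall is thought more likely than a rise. Among the compounds with values here, the expectation rests on compound 1 at 76% as its starting point, and nothing measured so far fixes the direction. The expected move is a number 6 percentage points lower from compound 1 to compound 4 (within the scatter) and would stay within the scatter. For compound 4 the estimated value is 70%, with an expected range from 54% to 84% in this read-out.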

Compound 4, percent growth inhibition at one concentration: 78%
The estimate for compound 4 lay 8 percentage points below the measured number; measured number inside the range.
By their numbers in this assay, from the lowest: compound 2; then compound 3; then compounds 1 and 4 (each within the scatter of the next).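

In this assay, furan-2-yl in place of thiophen-2-yl on a double-bonded chain carbon bound to a double-bonded chain carbon gives a number 2 percentage points higher from compound 1 to compound 4 (within the scatter) for this swap. Going by these compounds alone, this is the first step that can be read at one place, and it shows that the single hetero atom of this five-membered aromatic ring can be sulfur or oxygen without a difference beyond the scatter at the one concentration tested. Nothing measured on these compounds bears on this result, so the reading stays purely descriptive.

Going by these compounds, whether the same place also accepts a pyrrol-2-yl ring, a pyridin-2-yl ring or an unsubstituted phenyl ring stays open, as does whether the furan-2-yl for thiophen-2-yl swap reads the same with a pentyl chain in place of the ethyl chain. On these data alone, compound 2 and compound 3 each differ from compound 1 in more than one place, so what separates their values from that of compound 1 also remains open.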